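Para substituent swap on the shared core

The compounds below may be only part of what the source reports. "The series", "measured", "known", "first", "only" and "open" are said of these compounds alone.

Measured in a functional assay on the whole organism for inhibition of sodium-dependent dopamine transporter (Mus musculus); on this read-out lower numbers stand for an effect already at smaller amounts and higher numbers for an effect only at larger amounts of compound:
- compound 1 `CN1Cc2c(N)cccc2C(c2ccc(Cl)cc2)C1`: 1.5 mg/kg
- compound 2 `CN1Cc2c(N)cccc2C(c2ccc(F)cc2)C1`: 7.5 mg/kg

Compound 2 carries the highest of the two numbers; its nearest neighbour is compound 1, separated by the step of a 5.0-fold higher number from compound 1 to compound 2 (0.70 log units; beyond the scatter). Among the measured compounds shown here, the only structural change in this pair is fluoro in place of chloro on the aromatic carbon.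

Compound 3 `Cc1ccc(C2CN(C)Cc3c(N)cccc32)cc1` differs from compound 2 by methyl in place of fluoro on an aromatic carbon. For the measured compounds named here, the single measured step, a 5.0-fold higher number from compound 1 to compound 2 (0.70 log units; beyond the scatter), shows that the group on this aromatic carbon moves the number in this assay by a modest amount, with chloro giving the lower number. Methyl has the same heavy-atom count as fluoro, so no larger movement is expected than that step. On this basis compound 3 is expected to land between the two measured values, a step of a 3.0-fold lower number from compound 2 to compound 3 (0.48 log units; beyond the scatter), giving an estimate of 2.5 mg/kg with a range from 1 mg/kg to 6.5 mg/kg.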

Compound 3, dose for half-maximal effect: about 22 mg/kg
The estimate for compound 3 lay 8.8-fold (0.94 log units) below the measured number; measured number above the stated range.
By their numbers in this assay, from the lowest: compound 1; then compound 2; then compound 3.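

In this assay, the group on this aromatic carbon, para to a large group, now covers a wider range than chloro and fluoro alone showed: a 15-fold higher number from compound 1 to compound 3 (1.17 log units; beyond the scatter) is a large step, and a 2.9-fold higher number from compound 2 to compound 3 (0.47 log units; beyond the scatter) adds a modest one. Fluoro and methyl each count 1 heavy atom, so an equal heavy-atom count does not give an equal number here, and the three compounds rank chloro, fluoro, methyl from the lowest number upward. Nothing at hand accounts for this order.

From the compounds shown here alone, whether the low number is particular to chloro remains open; bromo, trifluoromethyl, methoxy or a plain hydrogen on this carbon would test that. Also open, going by these compounds, is whether the same order holds on any core other than the shared one.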